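The compounds below may be only part of what the source reports. "The series", "measured", "known", "first", "only" and "open" are said of these compounds alone.

Series notes. The shared core of compound 1 `CCCN(CC[C@H]1CC[C@H](NC(=O)/C=C/c2cccc(OC)c2)CC1)[C@H]1CCc2nc(N)sc2C1` carries an amide whose acyl part varies. In an assay on brain for displacement of a labelled ligand from D(3) dopamine receptor (Rattus norvegicus) (on this read-out higher numbers stand for weaker inhibition and lower numbers for stronger inhibition), compound 1 gives 9.3 nM; compound 2 `CCCN(CC[C@H]1CC[C@H](NC(=O)c2cccc3cnccc23)CC1)[C@H]1CCc2nc(N)sc2C1` gives 5.9 nM; compound 3 `CCCN(CC[C@H]1CC[C@H](NC(=O)c2ccc(-n3cncn3)cc2)CC1)[C@H]1CCc2nc(N)sc2C1` gives 2.4 nM. Compound 3 has the lowest number of the three, with a 3.9-fold lower number from compound 1 to compound 3 (0.59 log units; beyond the scatter) and a 2.5-fold lower number from compound 2 to compound 3 (0.39 log units; beyond the scatter), while a 1.6-fold lower number from compound 1 to compound 2 (0.20 log units; within the scatter) is within the scatter.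

Compound 4 `CCCN(CC[C@H]1CC[C@H](NC(=O)c2ccc(-c3noc(C4CC4)n3)cc2)CC1)[C@H]1CCc2nc(N)sc2C1` differs from compound 3 by 5-cyclopropyl-1,2,4-oxadiazol-3-yl in place of 1H-1,2,4-triazol-1-yl on an aromatic carbon. Among the compounds with values here, no measured step here exchanges one five-membered aromatic ring for another at this place; the two steps that bear on it only show that an aromatic ring bearing such a group at this position reached the lowest number so far, by a 3.9-fold lower number from compound 1 to compound 3 (0.59 log units; beyond the scatter) and a 2.5-fold lower number from compound 2 to compound 3 (0.39 log units; beyond the scatter). A step of no more than modest size in this assay is therefore expected for compound 4, with direction uncertain, and a 1.2-fold lower number from compound 3 to compound 4 (0.08 log units; within the scatter) is the estimate. Compound 4 is expected to give about 2 nM in this assay, within a range of 0.6 nM to 7 nM.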

Compound 4, inhibition constant: 3.5 nM
Compound 4: the middle estimate sits 1.8-fold (0.24 log units) below what was measured, and the stated range covers the measured number.
By their numbers in this assay, from the lowest: compounds 3, 4, 2 and 1 (each within the scatter of the next, the first and the last beyond it).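

In this assay, the exchange gives a 1.5-fold higher number from compound 3 to compound 4 (0.16 log units; within the scatter), so at this place, on an aromatic carbon para to a large group, the 5-cyclopropyl-1,2,4-oxadiazol-3-yl and 1H-1,2,4-triazol-1-yl groups cannot be told apart. Within the data shown here, this is the first comparison of one five-membered aromatic ring with another here, and the entering group brings a cyclopropyl ring and more heavy atoms without a step beyond the scatter, while the counts of hydrogen-bond donors and acceptors stay the same. No measured evidence bears on why the two groups read alike.

Still open, as far as these compounds go, is whether a carboxylic acid or an aminomethyl group at this same place would keep the number in this range. Also open, from the compounds shown here alone, is whether a longer alkyl chain in place of the cyclopropyl would leave it unchanged.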